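Isobutoxy to sec-butoxy on the shared core

The source may hold more compounds than are shown below. What is called first, only, known or untested is meant among the compounds shown, and "the series" means these compounds.

Measured so far in a functional assay on the whole organism (strain Sprague-Dawley) for inhibition, with Rattus norvegicus as the target, with a stated time of 10 min (a lower number here means that less compound is needed, a higher number that more compound is needed for the effect), with these values:
- compound 1 `CCOC(=O)c1cnc(-c2ccccc2O)[nH]c1=O` gives 5 mg/kg
- compound 2 `CCOC(=O)c1cnc(-c2ccccc2OCC(C)C)[nH]c1=O` gives 3 mg/kg

Compound 2 cannot be separated from compound 1 on these numbers. Among the compounds with values here, the only measured step is a 1.7-fold lower number from compound 1 to compound 2 (0.22 log units; within the scatter) and it stays inside the scatter.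

Compound 3 `CCOC(=O)c1cnc(-c2ccccc2OC(C)CC)[nH]c1=O` carries sec-butyl in place of isobutyl on an oxygen on an aromatic ring and keeps the rest of compound 2 unchanged. Within the data shown here, the one measured step bearing on this swap puts isobutyl in place of hydrogen on that oxygen, and that step for compound 2 was a 1.7-fold lower number from compound 1 to compound 2 (0.22 log units; within the scatter) with no clear change. No shift beyond the scatter is therefore expected, and the estimated step is no change at the digits printed from compound 2 to compound 3 (within the scatter) in either direction. Compound 3 is expected at 3 mg/kg (estimated range 1.3 mg/kg to 7 mg/kg).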

Compound 3, dose for 50% inhibition: 0.5 mg/kg
Estimate against measurement, compound 3: 6.0-fold (0.78 log units) above; the measured number lies below the stated range.
By their numbers in this assay, from the lowest: compound 3; then compounds 2 and 1 (each within the scatter of the next).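

In this assay this position on the oxygen on the aromatic ring responds to how the chain is joined, not only to whether a chain is present: with the same atoms on both sides, the swap from isobutyl to sec-butyl gives a 6.0-fold lower number from compound 2 to compound 3 (0.78 log units; beyond the scatter) on the shared core. Measured against the free hydrogen on that oxygen, sec-butyl gives a 10-fold lower number from compound 1 to compound 3 (1.00 log units; beyond the scatter), a step beyond the scatter that isobutyl did not produce. Nothing in hand accounts for the difference between these two isomeric groups.

Open, on these data alone, is whether isopropyl or a longer branched chain such as sec-pentyl on the same oxygen holds the lower number seen for compound 3. Also open, as far as these compounds go, is whether the two mirror-image forms of sec-butyl behave alike, since compound 3 is drawn without a defined configuration.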